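The compounds below may be only part of what the source reports. "The series", "measured", "known", "first", "only" and "open" are said of these compounds alone.

Measured so far:
Compound 1 `O=C(O)c1cncc(CN2CCC[C@H](O[C@H](CO)c3cc(Cl)cc(Cl)c3)[C@@H]2c2ccccc2)c1` — in an assay on isolated protein for activation of cGMP-dependent protein kinase 1 (Homo sapiens), read by ADP-Glo, with stated times of 120 min and 40 min (a lower number here means that less compound is needed, a higher number that more compound is needed for the effect), compound 1 gives 34000 nM.
Compound 2 `OC[C@@H](O[C@H]1CCCN(Cc2ncc[nH]2)[C@H]1c1ccccc1)c1cc(Cl)cc(Cl)c1` — compound 2 gives 7000 nM.

Compound 2 has the lower of the two numbers; the step of a 4.9-fold lower number from compound 1 to compound 2 (0.69 log units; beyond the scatter) separates it from compound 1. Compound 3 `O=C(O)c1ccc(CN2CCC[C@H](O[C@H](CO)c3cc(Cl)cc(Cl)c3)[C@@H]2c2ccccc2)cc1` differs from compound 2 in that (4-carboxyphenyl in place of 1H-imidazol-2-yl on a saturated chain carbon bound to an amine nitrogen in a ring). Among the compounds with values here, only one measured step bears on this: a 4.9-fold lower number from compound 1 to compound 2 (0.69 log units; beyond the scatter), where a carboxylated aryl group gave way to the imidazolyl and the number fell. Returning to a carboxylated aryl group is therefore expected to raise the number again, roughly back toward compound 1. Compound 3 is expected at 20000 nM, with a range of 6000 nM to 60000 nM. That expectation amounts to a step of a 2.9-fold higher number from compound 2 to compound 3 (0.46 log units; beyond the scatter).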

Compound 3, half-maximal effective concentration in the cGMP-dependent protein kinase 1 assay: 11000 nM
For compound 3 the middle estimate is 1.8-fold (0.26 log units) above the measured one; the range from low to high includes it.
By their numbers in the cGMP-dependent protein kinase 1 assay, from the lowest: compounds 2 and 3 (each within the scatter of the next); then compound 1.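

In the cGMP-dependent protein kinase 1 assay compound 3 gives 11000 nM, so a carboxylated aryl group does not by itself keep the number high at this place: 4-carboxyphenyl cannot be told apart from 1H-imidazol-2-yl (a 1.6-fold higher number from compound 2 to compound 3 (0.20 log units; within the scatter)). The two carboxylated aryl groups do differ from each other (a 3.1-fold lower number from compound 1 to compound 3 (0.49 log units; beyond the scatter)), so compound 1 stands apart from compound 2 and compound 3. Nothing available here explains that gap between the two aryl groups. In a physicochemical assay for solubility, read by HPLC, with a stated time of 24 h, at pH 7 (a lower number here means a less soluble compound, a higher number a more soluble compound), compound 2 gives 60000 nM and compound 3 gives 85000 nM, and these two values cannot be told apart (a 1.4-fold higher number from compound 2 to compound 3 (0.15 log units; within the scatter)).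

As far as these compounds go, it remains open whether an amide or a tetrazole in place of the carboxylic acid of 4-carboxyphenyl would give a number like that of compound 3. From the compounds shown here alone, it also remains open whether a longer chain to the amine nitrogen would change it.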